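A few compounds are considered here, and "the series" means these few. Any claim that something is new, unique, unknown or untested is made for them only; others in the source may bear on it.

Compound 1 `CCCCCc1ccc(-c2cn(C/C=C3\OC(=O)C(OCc4ccccc4)=C3OCc3ccccc3)nn2)cc1`: > 100000 nM (a limit)
Compound 2 `CCCCCCCCCCc1cn(C[C@H](O)[C@H]2OC(=O)C(OCc3ccccc3)=C2OCc2ccccc2)nn1`: 12200 nM
Compound 3 `O=C1O/C(=C\Cn2cc(-c3cccc(O)c3)nn2)C(OCc2ccccc2)=C1OCc1ccccc1`: 61700 nM

These values come from a functional assay on HepG2 cells (Homo sapiens) for antiproliferative activity, read by MTT assay, with a stated time of 72 h; on this read-out higher numbers stand for weaker inhibition and lower numbers for stronger inhibition. The entry for compound 1 is a limit of the assay and not a number. Of the two true numbers, compound 2 has the lower at 12200 nM. The nearest is compound 3 at 61700 nM, and that gap lies beyond the scatter.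

Compound 4 `C[Si](C)(C)c1cn(C[C@H](O)[C@H]2OC(=O)C(OCc3ccccc3)=C2OCc2ccccc2)nn1` has not yet been measured. It departs from compound 2 at one place, on an aromatic carbon of a five-membered aromatic ring with 3 nitrogen, where the decyl group gives way to a smaller group: a group of 4 heavy atoms (3 carbon, 1 silicon; no ring) in place of a group of 10 heavy atoms (10 carbon; no ring), on an aromatic carbon.

For the measured compounds named here, no measured step makes this same exchange. The closest is an at least 1.6-fold lower number from compound 1 to compound 3 (0.20 log units; that floor lies within the scatter), also a swap on an aromatic carbon, but on the core of compound 1, and its floor lies within the scatter. It therefore offers only weak guidance on size or direction. Compound 2 holds the lowest number shown at 12200 nM, so a change away from it seems more likely to raise the number than to lower it. The expected step in this assay is a 2.5-fold higher number from compound 2 to compound 4 (0.39 log units; beyond the scatter), a modest move towards weaker inhibition. For compound 4 the estimated value is 30000 nM, with an expected range of 8000 nM to 100000 nM.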

Compound 4, half-maximal inhibitory concentration: 24100 nM
Beside the measured number, compound 4's estimate is 1.2-fold (0.10 log units) above it, and the stated range covers the measured number.
By their numbers in this assay, from the lowest: compounds 2 and 4 (each within the scatter of the next); then compound 3. At a limit, above all of these: compound 1.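

In this assay, replacing the decyl group with the group of 4 heavy atoms (3 carbon, 1 silicon) on the aromatic carbon of the five-membered ring gives a 2.0-fold higher number from compound 2 to compound 4 (0.30 log units; within the scatter). On this shared core, then, the two compounds cannot be told apart, and the long decyl chain is not needed for the activity seen here, since a group with far fewer heavy atoms and no longer chain serves within the scatter. For the compounds shown here, the earlier compounds could not show this, as the only earlier step on an aromatic carbon was made on a different core and gave just a floor, because compound 1 stands at a limit of the assay and not at a number: the limit of > 100000 nM in this assay, at which 1 of the 4 values shown sits.

From the compounds shown here alone, how a tert-butyl group at this position would compare with the silicon-bearing group stays open, and with it whether the silicon atom itself matters at all. Equally open, going by these compounds, is how an amine or a carboxylic acid on this carbon would read in this assay, and whether a chain of intermediate length, such as hexyl, would fall within the same scatter.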